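Propoxy for butyl on a cyclohexylbenzimidazole urea series

This account rests on a few compounds, and the source may have more. Where it says the series, first, only, none or still open, it means among the compounds named here.

Compound 1 `CCCCNC(=O)Nc1cc2nc(C3CCCCC3)[nH]c2cc1N(CC)CC` in an ADME assay on Vero cells (Chlorocebus sabaeus) for cytotoxicity, read by resazurin assay, with a stated time of 3 days (a higher number here means a weaker inhibitor, a lower number a stronger inhibitor), gives > 100 ug/mL, which is a limit of the assay rather than a number, the point marked by the limit of > 100 ug/mL in this assay, at which 1 of the 2 values shown sits. Compound 2 `CCCCCC(=O)Nc1cc2nc(C3CCCCC3)[nH]c2cc1N(CC)CC` carries a hexanamide in place of the urea, and for compound 2 the result in this assay is "not determined" (no result reported), so compound 2 has no number to stand on. Compound 3 `CCCOCC(=O)Nc1cc2nc(C3CCCCC3)[nH]c2cc1N(CC)CC` differs from compound 2 by propoxy in place of butyl on a saturated chain carbon bound to a carbonyl carbon. For the measured compounds named here, with no measured step to lean on, a step in this assay from compound 2 to compound 3 of no size beyond the scatter is expected. For compound 3 in this assay the expected value is 100 ug/mL, and the expected range runs from 50 ug/mL to 200 ug/mL.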

Compound 3, half-maximal inhibitory concentration: > 100 ug/mL
Compound 3 gave a limit, no number; the forecaster's own chance of this, stated with the estimate: 70%; the middle value sits exactly at the limit.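

No step can be read from compound 1 to compound 3, as both results are limits, not numbers: the limit of > 100 ug/mL in this assay, at which 2 of the 3 values shown sit.

The compounds shown leave open how compound 1 and compound 3 compare in this assay, and what propoxy in place of butyl does there.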